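The compounds below may be only part of what the source reports. "The series", "measured", "known", "first", "only" and "open" are said of these compounds alone.

Compound 2, `CCCc1n[nH]c2c(=O)n(NC(=O)c3ccccc3)c(-c3cccc([N+](=O)[O-])c3)nc12`, stands highest of the three measured compounds in a functional assay on A549 cells (Homo sapiens) for cytotoxicity, read by sulforhodamine B assay, with a stated time of 2 days, tested at 100 uM (a higher number here means more inhibition at the concentration tested (going by the name of the read-out), a lower number less inhibition), giving 33.2%. Among the compounds with values here, compound 3, `CCCc1n[nH]c2c(=O)n(NC(=O)c3ccccc3)c(-c3cccc(OC)c3)nc12`, gives 20.7%, and the move a number 12.5 percentage points lower from compound 2 to compound 3 (beyond the scatter) is the only single-place step known. Compound 1, `O=C(Nn1c(-c2cccc([N+](=O)[O-])c2)nc2c(-c3ccc(Cl)cc3)n[nH]c2c1=O)c1cccnc1`, gives 19.7%; it differs from compound 2 in more than one place, so only the two values themselves can be compared. Compound 4, `O=C(Nn1c(-c2cccc([N+](=O)[O-])c2)nc2c(-c3ccc(F)cc3)n[nH]c2c1=O)c1ccccc1`, differs from compound 2 by 4-fluorophenyl in place of propyl on an aromatic carbon. Within the data shown here, no measured step touches this position, and the aryl-bearing compound 1 gives the lowest number of the set. Compound 4 is therefore expected to sit somewhat below compound 2, a step of a number 9.2 percentage points lower from compound 2 to compound 4 (within the scatter), with an estimated 24% in this assay, ranging from 10% to 40%.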

Compound 4, a percentage reported as inhibition, at one concentration (the size of the read-out at that concentration, not a potency): 80.7%
Compound 4: the middle estimate sits 56.7 percentage points below what was measured, outside the stated range (above it).
By their numbers in this assay, from the lowest: compounds 1 and 3 (each within the scatter of the next); then compound 2; then compound 4.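

In this assay, within the data shown here, the place on the five-membered aromatic ring with 2 nitrogen, which no earlier step touched, turns out to matter strongly: 4-fluorophenyl in place of propyl gives a number 47.5 percentage points higher from compound 2 to compound 4 (beyond the scatter) with the rest of the compound unchanged. This large step outweighs the modest one seen earlier on the nitro-bearing aromatic ring. No measurement here accounts for its size.

As far as these compounds go, how a plain phenyl or a pentyl chain at this place would compare stays open, so the ring and its fluorine cannot be told apart. From the compounds shown here alone, whether methoxy in place of nitro would lower the number of compound 4 also remains open.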